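Compound 1 to compound 4: changing the urea aryl group

This account rests on a few compounds, and the source may have more. Where it says the series, first, only, none or still open, it means among the compounds named here.

Measured in a functional assay on SK-MEL-2 cells (Homo sapiens) for inhibition, read by sulforhodamine B assay, with a stated time of 48 h; on this read-out lower numbers stand for higher toxicity in this test and higher numbers for lower toxicity in this test:
- compound 1 `O=C(Nc1cccc(-n2cc(-c3ccncc3)c(-c3ccc(Cl)c(O)c3)n2)c1)Nc1cccc(C(F)(F)F)c1`: > 32500 nM
- compound 2 `COc1cc(-c2nn(-c3cccc(NC(=O)Nc4cc(C(F)(F)F)cc(C(F)(F)F)c4)c3)cc2-c2ccncc2)ccc1Cl`: 3710 nM
- compound 3 `COc1cc(-c2nn(-c3cccc(NC(=O)Nc4ccc(Cl)c(Cl)c4)c3)cc2-c2ccncc2)ccc1Cl`: 4850 nM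

The read-out of compound 1 is a limit, > 32500 nM, and not a number. Compound 2 and compound 3 both give numbers, and these lie within the usual scatter of each other.

Compound 4 `O=C(Nc1cccc(-n2cc(-c3ccncc3)c(-c3ccc(Cl)c(O)c3)n2)c1)Nc1ccc(Cl)c(Cl)c1` is not yet measured. It carries 3,4-dichlorophenyl in place of 3-(trifluoromethyl)phenyl on an amide-type nitrogen. Among the compounds with values here, the only other compound with 3,4-dichlorophenyl is compound 3 at 4850 nM, although the core of compound 3 is not that of compound 1. A move towards lower concentrations, meaning higher toxicity, is therefore expected, but its size is uncertain and another limit remains possible. The expected step is an at least 2.7-fold lower number from compound 1 to compound 4 (0.43 log units; beyond the scatter). For compound 4 the estimated value is 12000 nM. The expected range runs from 3500 nM to 35000 nM.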

Compound 4, concentration lethal to 50% of the cells: > 32500 nM
Compound 4 gave a limit, no number; the forecaster's own chance of this, stated with the estimate: 35%; middle value at least 2.7-fold (0.43 log units) away from the limit.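

In this assay, 3,4-dichlorophenyl in place of 3-(trifluoromethyl)phenyl on the amide-type nitrogen still gives no number on the core of compound 1, and the step between these two compounds cannot be read. Hydrogen in place of methyl on an oxygen on an aromatic ring, with 3,4-dichlorophenyl held constant, gives the only readable step here, towards lower toxicity in this test: an at least 6.7-fold higher number from compound 3 to compound 4 (0.82 log units; beyond the scatter). Compound 1 and compound 4, the two with hydrogen on that oxygen, each give a limit and no number: the limit of > 32500 nM in this assay, at which 2 of the 4 values shown sit.

As far as these compounds go, the values of compound 1 and compound 4 beyond that limit remain open, so the two aryl groups cannot be ranked on this core. Also open, from the compounds shown here alone, is whether an ethyl group on that oxygen, or an amine in place of that oxygen, would give a number.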